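This account rests on a few compounds, and the source may have more. Where it says the series, first, only, none or still open, it means among the compounds named here.

In a physicochemical assay for solubility, at pH 7.4 (on this read-out lower numbers stand for lower solubility and higher numbers for higher solubility), compound 1 `CN(C)c1ccc(C(=O)N2CCC(NS(=O)(=O)c3cc(S(=O)(=O)c4ccccc4)ccc3C(F)(F)F)CC2)cn1` gives 6700 nM. Compound 2 `CC(C)(O)CCN1CCC(NS(=O)(=O)c2cc(S(=O)(=O)c3ccccc3)ccc2C(F)(F)F)CC1` gives > 100000 nM, which is a limit of the assay and not a number. Its standing is therefore (the limit of > 100000 nM in this assay, at which 1 of the 2 values shown sits). Compound 3 `O=C([C@H]1CCNC1)N1CCC(NS(=O)(=O)c2cc(S(=O)(=O)c3ccccc3)ccc2C(F)(F)F)CC1` differs from compound 2 by (pyrrolidin-3-yl)carbonyl in place of 3-hydroxy-3-methylbutyl on an amine nitrogen in a ring, with (pyrrolidin-3-yl)carbonyl in place of 3-hydroxy-3-methylbutyl on an amine nitrogen in a ring. Among the measured compounds shown here, only one measured step bears on this change: an at least 14-fold higher number from compound 1 to compound 2 (1.17 log units; beyond the scatter), which is large and beyond the scatter. It replaced a carbonyl-linked group on the same nitrogen with 3-hydroxy-3-methylbutyl, and compound 3 restores a carbonyl there, though with a different group. A single step is thin ground, but a fall smaller than that step is expected in this assay. The expected change is an at least 1.6-fold lower number from compound 2 to compound 3 (0.22 log units; that floor lies within the scatter). Compound 3 is estimated at 60000 nM, with an expected range of 15000 nM to 100000 nM.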

Compound 3, solubility: 77000 nM
Compound 3: the middle estimate sits 1.3-fold (0.11 log units) below what was measured; low and high end bracket the measured number.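

A carbonyl on the amine nitrogen in a ring can therefore go with a high number in this assay: pyrrolidin-3-yl in place of 6-(dimethylamino)pyridin-3-yl on the carbonyl carbon gives an 11-fold higher number from compound 1 to compound 3 (1.06 log units; beyond the scatter). Putting (pyrrolidin-3-yl)carbonyl in place of 3-hydroxy-3-methylbutyl gives an at least 1.2-fold lower number from compound 2 to compound 3 (0.11 log units; that floor lies within the scatter), so this comparison does not separate the two groups. Compound 2 gives > 100000 nM, which is a limit of the assay and not a number, and the true size of that step stays unknown because of this limit: the limit of > 100000 nM in this assay, at which 1 of the 3 values shown sits.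

Going by these compounds, it remains open whether the number holds with a cyclopentyl on the same carbonyl, which would remove the ring nitrogen, or with an acetyl on that nitrogen. The compounds shown also leave open how the other stereoisomer of the pyrrolidin-3-yl group would read.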